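The compounds below may be only part of what the source reports. "The series", "measured", "known", "first", "only" and "open" are said of these compounds alone.

Compound 3 `CCNC(=O)/C=C/c1c(/C=C/c2ccc(OC)cc2)cc(OC)cc1OC` gives 6990 nM in a functional assay on B16-F10 cells (Mus musculus) for inhibition, read by MTT assay, with a stated time of 48 h (on this read-out higher numbers stand for weaker inhibition and lower numbers for stronger inhibition), which places it second highest among the three measured compounds. Its nearest neighbour on the numbers is compound 1 `COc1ccc(/C=C/c2cc(OC)cc(OC)c2/C=C/C(=O)N2CCN(C)CC2)cc1`, which gives 5670 nM, and the furthest is compound 2 `CCCCN(CCCC)C(=O)/C=C/c1c(/C=C/c2ccc(OC)cc2)cc(OC)cc1OC`, which gives 9030 nM. Each of these gaps lies within the scatter: a 1.2-fold higher number from compound 1 to compound 3 (0.09 log units; within the scatter), a 1.3-fold lower number from compound 2 to compound 3 (0.11 log units; within the scatter), and a 1.6-fold higher number from compound 1 to compound 2 (0.20 log units; within the scatter). Compound 4 `COc1ccc(/C=C/c2cc(OC)cc(OC)c2/C=C/C(=O)N(CC(C)C)CC(C)C)cc1` differs from compound 3 in one place: diisobutylamino in place of ethylamino on a carbonyl carbon. The measured step that bears most directly on this change is the one in which ethylamino replaced dibutylamino on a carbonyl carbon, a 1.3-fold lower number from compound 2 to compound 3 (0.11 log units; within the scatter), and the other two exchanges at the same carbonyl carbon were likewise within the scatter. On these numbers the group on the carbonyl carbon has not moved the read-out beyond the scatter, so no step beyond the scatter is expected in this assay. On that basis the expected step is a 1.1-fold higher number from compound 3 to compound 4 (0.06 log units; within the scatter). For compound 4 the estimate in this assay is 8000 nM, with a range from 4000 nM to 16000 nM.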

Compound 4, half-maximal inhibitory concentration: 4850 nM
The estimate for compound 4 lay 1.6-fold (0.22 log units) above the measured number; low and high end bracket the measured number.
By their numbers in this assay, from the lowest: compounds 4, 1, 3 and 2 (each within the scatter of the next).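

In this assay, diisobutylamino on the carbonyl carbon stays within the scatter of ethylamino (a 1.4-fold lower number from compound 3 to compound 4 (0.16 log units; within the scatter)), of dibutylamino (a 1.9-fold lower number from compound 2 to compound 4 (0.27 log units; within the scatter)) and of 4-methylpiperazin-1-yl (a 1.2-fold lower number from compound 1 to compound 4 (0.07 log units; within the scatter)). The exchange of ethylamino for diisobutylamino removes the amide hydrogen and adds to the heavy-atom count without a step beyond the scatter, and even the widest gap among the four compounds, between the two amino groups with butyl and isobutyl chains, stays within it. No measurement at hand offers an explanation for this flat picture.

From the compounds shown here alone, it remains open whether an amide carrying a carboxylic acid, a primary amine or a much longer chain at this carbonyl carbon would move the number beyond the scatter. Also open, going by these compounds, is whether hydroxyl in place of the methoxy groups on the shared core would do so.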